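Urea-to-anilide change in a pyrazole series: compound 4

This account rests on a few compounds, and the source may have more. Where it says the series, first, only, none or still open, it means among the compounds named here.

Measured so far:
Compound 1 `COc1cc(Cl)cc(-c2nn(-c3cccc(NC(=O)Nc4ccc(Cl)c(C(F)(F)F)c4)c3)cc2-c2ccncc2)c1`: 17% in a functional assay on RPMI-8226 cells (Homo sapiens) for inhibition, read by sulforhodamine B assay, with a stated time of 48 h, tested at 1 uM; on this read-out higher numbers stand for a weaker effect at the one concentration tested and lower numbers for a stronger effect
Compound 2 `COc1cc(Cl)cc(-c2nn(-c3cccc(NC(=O)Nc4ccc(Cl)c(Cl)c4)c3)cc2-c2ccncc2)c1`: 39%
Compound 3 `COc1cc(Cl)cc(-c2nn(-c3cccc(NC(=O)Nc4cccc(C(F)(F)F)c4)c3)cc2-c2ccncc2)c1`: 22%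

Compound 3 stands second highest of the three numbers in this assay; its nearest neighbour is compound 1, where the difference a number 5 percentage points higher from compound 1 to compound 3 (within the scatter) lies within the scatter, and its furthest is compound 2, where a number 17 percentage points lower from compound 2 to compound 3 (beyond the scatter) is a modest step beyond it. The other measured step, a number 22 percentage points higher from compound 1 to compound 2 (beyond the scatter), is also modest.

Compound 4 `COc1cc(Cl)cc(-c2nn(-c3cccc(NC(=O)c4cccc(C(F)(F)F)c4)c3)cc2-c2ccncc2)c1` differs from compound 3 by 3-(trifluoromethyl)phenyl in place of (3-(trifluoromethyl)phenyl)amino on a carbonyl carbon. All three measured steps vary the distal aromatic ring; none of them touches the carbonyl carbon or the amide-type nitrogen, so none bears on this change. The expectation for compound 4 therefore rests on the value of compound 3 alone, with a wide range and no preferred direction: compound 4 is estimated at 35% (range 15% to 65%), an expected step of a number 13 percentage points higher from compound 3 to compound 4 (beyond the scatter).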

Compound 4, a percentage reported as activity, at one concentration (the size of the read-out at that concentration, not a potency): 79%
For compound 4 the middle estimate is 44 percentage points below the measured one; measured number above the stated range.
By their numbers in this assay, from the lowest: compounds 1 and 3 (each within the scatter of the next); then compound 2; then compound 4.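

In this assay, the change on the carbonyl carbon outweighs every distal ring change seen so far, giving a number 57 percentage points higher from compound 3 to compound 4 (beyond the scatter), toward a weaker effect at the one concentration tested. The anilide also sits well above both chlorinated ureas, with a number 40 percentage points higher from compound 2 to compound 4 (beyond the scatter) and a number 62 percentage points higher from compound 1 to compound 4 (beyond the scatter), although these two steps also change the ring substituents. No measurement shown here accounts for the loss.

Going by these compounds, whether any link other than the urea amino keeps the effect remains open, for example a methylene or a carbamate oxygen. Also open, on these data alone, is whether a 4-chloro substituent on the anilide ring changes the result.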